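Notes on a halogen swap carried to a second core

A few compounds are considered here, and "the series" means these few. Any claim that something is new, unique, unknown or untested is made for them only; others in the source may bear on it.

Measured so far:
compound 1 `O=C(O)c1ccc(CCCN2C(=O)CCC2CCC(O)Cc2ccc(F)cc2)cc1` — 2770 nM
compound 2 `O=C(O)c1ccc(CCCN2C(=O)CC[C@@H]2CC[C@@H](O)Cc2ccc(F)cc2)s1` — 70 nM
compound 3 `O=C(O)c1ccc(CCCN2C(=O)CCC2CCC(O)Cc2cccc(Cl)c2)cc1` — 42 nM

All three numbers come from an assay on HEK293 cells for binding affinity to prostaglandin E2 receptor EP4 subtype (Rattus norvegicus); on this read-out lower numbers stand for stronger inhibition and higher numbers for weaker inhibition. The change from compound 1 to compound 3 is 3-chlorophenyl in place of 4-fluorophenyl on a saturated chain carbon, two bonds along the chain from an oxygen on a saturated carbon, and it made the step of a 66-fold lower number from compound 1 to compound 3 (1.82 log units; beyond the scatter). Compound 2 rests on a different core from compound 1; the difference between the two cores is not broken down here. Compound 2 and compound 3 lie within the scatter of each other, so no order between them is read from their two values.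

Compound 4 `O=C(O)c1ccc(CCCN2C(=O)CC[C@@H]2CC[C@@H](O)Cc2cccc(Cl)c2)s1` is still to be measured. It differs from compound 2 by 3-chlorophenyl in place of 4-fluorophenyl on a saturated chain carbon, two bonds along the chain from an oxygen on a saturated carbon, the same change as from compound 1 to compound 3, now on the core of compound 2. A step of an 18-fold lower number from compound 2 to compound 4 (1.24 log units; beyond the scatter) is expected from compound 2 to compound 4 in this assay, smaller than the earlier one, because a 66-fold lower number from compound 1 to compound 3 (1.82 log units; beyond the scatter) was measured on the core of compound 1 while compound 2 already starts from 70 nM, leaving less room for a full repeat. Compound 4 is therefore estimated at about 4 nM, with a likely range from 1 nM to 20 nM.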

Compound 4, half-maximal inhibitory concentration: 1.1 nM
Compound 4: the middle estimate sits 3.6-fold (0.56 log units) above what was measured, within the range that was stated.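

In this assay, 3-chlorophenyl in place of 4-fluorophenyl on the core of compound 2 gives a 64-fold lower number from compound 2 to compound 4 (1.80 log units; beyond the scatter), and the step matches the one seen on the core of compound 1: the same change on two cores in this assay, a 66-fold lower number (1.82 log units; beyond the scatter) from compound 1 to compound 3 and a 64-fold lower number (1.80 log units; beyond the scatter) from compound 2 to compound 4, 1.0-fold (0.02 log units) apart, within the scatter of two such steps Across these two pairs, the change therefore carries from one core to the other with no difference in size that can be read beyond the scatter. This does not show that the step would hold on any further core, and it does not separate the effect of removing 4-fluorophenyl's fluorine from that of introducing the chlorine of 3-chlorophenyl, as both differences arrive in a single change; the two pairs also say nothing about what separates the two cores themselves.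

The compounds shown leave open how an unsubstituted phenyl, or a phenyl carrying bromine or trifluoromethyl, would compare on either core. They also leave open whether a tetrazole in place of the carboxylic acid would keep this step.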